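Adding an ester to a compound at the assay limit

This account rests on a few compounds, and the source may have more. Where it says the series, first, only, none or still open, it means among the compounds named here.

In a functional assay on MCF7 cells (Homo sapiens) for cytotoxicity, read by MTT assay, with a stated time of 24 h (on this read-out higher numbers stand for weaker inhibition and lower numbers for stronger inhibition), compound 1 `COc1ccc2[nH]c(-c3cc(OC)c(OC)c(OC)c3)cc2c1` gives > 30000 nM as a limit and not a number. Compound 2 `COc1ccc2c(c1)cc(-c1cc(OC)c(OC)c(OC)c1)n2Cc1ccccc1` gives > 30000 nM as a limit too, so its true value is not shown. Going by the values given here, that leaves a step that the two limits leave unreadable from compound 1 to compound 2 as the only measured step, and it offers no size to carry forward. Compound 3 `CCOCC(=O)Oc1ccc(Cn2c(-c3cc(OC)c(OC)c(OC)c3)cc3cc(OC)ccc32)cc1` differs from compound 2 by ((ethoxymethyl)carbonyl)oxy in place of hydrogen on an aromatic carbon with ((ethoxymethyl)carbonyl)oxy in place of hydrogen on an aromatic carbon, para to a large group. The expected change is an at least 1.2-fold lower number from compound 2 to compound 3 (0.07 log units; that floor lies within the scatter) and any shift should be small and towards stronger inhibition. The estimate for compound 3 is 25000 nM with an expected range from 5000 nM to 60000 nM and a report of only a limit remains likely.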

Compound 3, half-maximal inhibitory concentration: > 30000 nM
Compound 3: only a limit was reported; the forecaster's own chance of this, stated with the estimate: 65%; at least 1.2-fold (0.07 log units) between middle value and limit.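

Compound 3 gives > 30000 nM, a limit and not a number, so no step can be read from compound 2 to compound 3. Whether ((ethoxymethyl)carbonyl)oxy changes inhibition at all stays open, as every reading stops at one point: the limit of > 30000 nM in this assay, at which 3 of the 3 values shown sit.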